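Adding a chloro group to an inactive anilino compound

This account rests on a few compounds, and the source may have more. Where it says the series, first, only, none or still open, it means among the compounds named here.

In a functional assay on Bel-7402 cells (Homo sapiens) for inhibition, read by MTT assay, with a stated time of 24 h, tested at 0.1 ug/mL (on this read-out higher numbers stand for more inhibition of growth at the one concentration tested and lower numbers for less inhibition of growth), compound 1 (`O=C(O)CCCCC(CCSC(=O)c1ccccc1)SC(=O)c1ccccc1`) gives 1.09%. Compound 2 (`O=C(CCCCC(CCSC(=O)c1ccccc1)SC(=O)c1ccccc1)Nc1ccccc1`) carries a phenylcarbamoyl group at the end of the chain and is reported as "not active" (no number reported). Compound 2 therefore has no single number, only a verdict in words, so it cannot be placed exactly on the scale or set against compound 1 as a measured step.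

Compound 3 (`O=C(CCCCC(CCSC(=O)c1ccccc1)SC(=O)c1ccccc1)Nc1ccccc1Cl`) has not yet been measured. The structural change is chloro in place of hydrogen on an aromatic carbon. This places chloro in place of hydrogen on an aromatic carbon, ortho to a large group, turning phenylcarbamoyl into (2-chlorophenyl)carbamoyl. For the measured compounds named here, no measured pair shows what such a change does in this assay, so there is no direct evidence for its size or direction. The closest reference is compound 2 at "not active" (no number reported), and the step expected from it is none beyond the usual scatter, with neither direction favoured. Compound 3 is expected to give 3%, with an estimated range from 0% to 14%.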

Compound 3, percent growth inhibition at one concentration: 5.72%
Compound 3: the middle estimate sits 2.7 percentage points below what was measured; measured number inside the range.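

In this assay compound 3 gives 5.72%, so the (2-chlorophenyl)carbamoyl end of the chain comes with a number, which the phenylcarbamoyl end of compound 2 does not; the step from compound 2 to compound 3 cannot be read, as one side of it is a verdict in words, and the effect of the chloro group on its own stays unsized. Putting (2-chlorophenyl)amino in place of hydroxy on the carbonyl carbon gives a number 4.6 percentage points higher from compound 1 to compound 3 (within the scatter), so this exchange at the end of the chain leaves the two compounds indistinguishable at the one concentration tested. Nothing shown here offers an explanation for these readings.

The compounds shown leave open whether a fluoro, bromo or methyl group in the same place on the ring would read any differently in this assay. They also leave open what a simple amine or an ester at the end of the chain would do, and whether any compound of this kind can rise clearly beyond the scatter.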